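A few compounds are considered here, and "the series" means these few. Any claim that something is new, unique, unknown or untested is made for them only; others in the source may bear on it.

Going by the values given here, compound 2 `CCCCOC(=O)NS(=O)(=O)c1sc(CC(C)C)cc1-c1ccc(C(=O)c2ncco2)cc1` stands at the higher of the two numbers so far: in an assay on membranes from uterus for displacement of a labelled ligand from Angiotensin type II receptor (Sus scrofa), with a stated time of 1.5 h (on this read-out higher numbers stand for weaker inhibition and lower numbers for stronger inhibition), compound 2 gives 13.8 nM, while compound 1 `CCCCOC(=O)NS(=O)(=O)c1sc(CC(C)C)cc1-c1ccc(Cc2nccs2)cc1` gives 3.2 nM, the step being a 4.3-fold higher number from compound 1 to compound 2 (0.63 log units; beyond the scatter). Compound 3 `CCCCOC(=O)NS(=O)(=O)c1sc(CC(C)C)cc1-c1ccc(CN2C(=O)N(C)C(C)(C)C2=O)cc1` differs from compound 2 by a group of 11 heavy atoms (7 carbon, 2 nitrogen, 2 oxygen; one five-membered non-aromatic ring with 2 hetero atoms) in place of a group of 7 heavy atoms (4 carbon, 1 nitrogen, 2 oxygen; one five-membered aromatic ring with 2 hetero atoms), on an aromatic carbon. Among the compounds with values here, the one measured step swapped two different groups at this position and so bears only loosely on the new change; it suggests that such swaps can move the number modestly, without telling the direction. Compound 3 is therefore expected to land close to compound 2, with an estimated step of a 1.1-fold higher number from compound 2 to compound 3 (0.04 log units; within the scatter). Compound 3 is expected to give about 15 nM, estimated between 4 nM and 60 nM.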

Compound 3, inhibition constant: 3.6 nM
Compound 3: middle estimate off by 4.2-fold (0.62 log units), on the high side; measured number outside the range, below it.
By their numbers in this assay, from the lowest: compounds 1 and 3 (each within the scatter of the next); then compound 2.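

Replacing the (1,3-oxazol-2-yl)carbonyl with the larger non-aromatic ring group on its saturated chain carbon gives a 3.8-fold lower number from compound 2 to compound 3 (0.58 log units; beyond the scatter). With that chain carbon kept, 3,4,4-trimethyl-2,5-dioxoimidazolidin-1-yl in place of 1,3-thiazol-2-yl gives a 1.1-fold higher number from compound 1 to compound 3 (0.05 log units; within the scatter), so in this pair an aromatic and a non-aromatic five-membered ring are not told apart. Nothing available explains this result. As far as these compounds go, compound 2 differs from compound 1 in both the ring and its link, so their separate shares remain open. From the compounds shown here alone, whether an amine or a carboxylic acid on that chain carbon would hold the number also remains open.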